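The compounds below may be only part of what the source reports. "The series", "measured", "known", "first", "only" and "open" are said of these compounds alone.

Values in a functional assay on MCF7 cells (Homo sapiens) for antiproliferative activity, read by MTT assay, with a stated time of 24 h (on this read-out lower numbers stand for stronger inhibition and higher numbers for weaker inhibition), for the measured compounds
Compound 1 `O=[N+]([O-])c1ccc(S(=O)(=O)n2c(-c3cn(-c4ccccc4)nc3-c3ccc(F)cc3)nc3ccccc32)cc1` gives 1370 nM
Compound 2 `O=S(=O)(c1ccc(C(F)(F)F)cc1)n1c(-c2cn(-c3ccccc3)nc2-c2ccc(F)cc2)nc2ccccc21` gives 1580 nM
Compound 3 `O=[N+]([O-])c1ccc(S(=O)(=O)n2c(-c3cn(-c4ccccc4)nc3-c3ccc(C(F)(F)F)cc3)nc3ccccc32)cc1` gives 1130 nM

Compound 3 lies within the scatter of both compound 1 and compound 2 in this assay and so cannot be ranked against either of them. Compound 4 `O=S(=O)(c1ccc(C(F)(F)F)cc1)n1c(-c2cn(-c3ccccc3)nc2-c2ccc(C(F)(F)F)cc2)nc2ccccc21` differs from compound 3 by a single change trifluoromethyl in place of nitro on an aromatic carbon in which trifluoromethyl takes the place of nitro on an aromatic carbon, para to a large group. The same replacement has been measured once, as the step of a 1.2-fold higher number from compound 1 to compound 2 (0.06 log units; within the scatter) and it did not rise above the noise. The other measured step, a 1.2-fold lower number from compound 1 to compound 3 (0.08 log units; within the scatter) is a different replacement at another site, and it too remains small. Neither step gives reason to expect a real shift, so no change beyond the scatter is expected for this replacement. The step expected here is a 1.2-fold higher number from compound 3 to compound 4 (0.06 log units; within the scatter) and it carries no firm direction. For compound 4 the estimated value is 1300 nM (expected range 750 nM to 2200 nM).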

Compound 4, half-maximal inhibitory concentration: 1240 nM
Compound 4: the middle estimate sits 1.0-fold (0.02 log units) above what was measured; measured number inside the range.
By their numbers in this assay, from the lowest: compounds 3, 4, 1 and 2 (each within the scatter of the next).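

In this assay, the change from 4-nitrophenyl to 4-(trifluoromethyl)phenyl gives a 1.1-fold higher number from compound 3 to compound 4 (0.04 log units; within the scatter), so this replacement can now be read on a second core, and it stays small on both: the same change on two cores in this assay, a 1.2-fold higher number (0.06 log units; within the scatter) from compound 1 to compound 2 and a 1.1-fold higher number (0.04 log units; within the scatter) from compound 3 to compound 4, 1.1-fold (0.02 log units) apart, within the scatter of two such steps The other replacement, trifluoromethyl in place of fluoro on an aromatic carbon, also gains a second reading with a 1.3-fold lower number from compound 2 to compound 4 (0.11 log units; within the scatter), and it behaves alike on both cores: the same change on two cores in this assay, a 1.2-fold lower number (0.08 log units; within the scatter) from compound 1 to compound 3 and a 1.3-fold lower number (0.11 log units; within the scatter) from compound 2 to compound 4, 1.1-fold (0.02 log units) apart, within the scatter of two such steps Neither replacement rises above the scatter on either core.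

The compounds shown carry only nitro or trifluoromethyl at this position, so it remains open whether an amine, a carboxylic acid or a methoxy group there would shift the number beyond the scatter. As far as these compounds go, it also remains open whether these small steps would hold on any other cell line.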